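From 3-fluorobenzyl to butyl in a cytotoxicity series

The compounds below may be only part of what the source reports. "The series", "measured", "known", "first", "only" and "open" are said of these compounds alone.

Three compounds sharing one core were tested in a functional assay on SV5A8 cells (Homo sapiens) for cytotoxicity; on this read-out lower numbers stand for stronger inhibition and higher numbers for weaker inhibition. Compound 1 `Cc1ccc2c(NCc3ccc(NC(=O)C4CCN(Cc5ccccc5)CC4)cc3)nc(N(C)CCCN(C)C)nc2c1` gives in this assay only a limit of the assay, > 8620 nM. Compound 3 `Cc1ccc2c(NCc3ccc(NC(=O)C4CCN(Cc5ccccc5)CC4)cc3)nc(N3CCCC3)nc2c1` likewise gives in this assay only a limit, > 7790 nM. Among the compounds with values here, the single change between them, a step that the two limits leave unreadable from compound 1 to compound 3, therefore cannot be read. Compound 2 `Cc1ccc2c(NCc3ccc(NC(=O)C4CCN(Cc5cccc(F)c5)CC4)cc3)nc(N(C)C)nc2c1` also gives in this assay only a limit, > 4170 nM. Compound 2 thus stands among three values that are all limits rather than numbers, and none of them can be ranked against another.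

Compound 4 `CCCCN1CCC(C(=O)Nc2ccc(CNc3nc(N(C)C)nc4cc(C)ccc34)cc2)CC1` differs from compound 2 in one place: propyl in place of 3-fluorophenyl on a saturated chain carbon bound to an amine nitrogen in a ring. Within the data shown here, no measured step bears on this change, and the only measured step in the set is itself unreadable. There is no ground for expecting a shift in either direction beyond the scatter, and the expectation is that compound 4 would again reach only a limit in this assay. The step this implies is estimated as a step that the limit leaves unreadable from compound 2 to compound 4. For compound 4 the estimate in this assay is 8000 nM, with a range from 3000 nM to 30000 nM.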

Compound 4, half-maximal inhibitory concentration: > 10500 nM
Compound 4 was reported as a limit; the forecaster's own chance of this, stated with the estimate: 80%; at least 1.3-fold (0.11 log units) between middle value and limit.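

In this assay compound 4 gives only a limit of the assay, > 10500 nM. Compound 2 also gives only a limit, so no step can be read between compound 2 and compound 4. The compounds shown leave open whether the change from 3-fluorobenzyl to butyl shifts the read-out at all, and in which direction.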